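The source may report more compounds than this note shows. Statements on the series, on what has been measured and on what is new or still open speak of the compounds shown alone.

Compound 1 `CC(C)=CCCC1=CC[C@H](C(=O)N(C)C)[C@@H](c2ccccc2)C1` is one of two measured compounds in an assay on isolated protein for inhibition of Apoptosis regulator Bcl-2 (Homo sapiens), read by fluorescence polarization, with stated times of 5 min and 10 min; a lower number here means a stronger inhibitor, a higher number a weaker inhibitor. In this assay compound 1 reaches only a limit, reported as > 23000 nM. Compound 2 `CC(C)=CCCC1=CC[C@H](C(=O)NCCC(=O)O)[C@@H](c2ccccc2)C1` likewise reaches only a limit, reported as > 23000 nM. Within the data shown here, the step between them, a step that the two limits leave unreadable from compound 1 to compound 2, therefore cannot be read, and the only evidence across the measured pair is the limit of > 23000 nM in this assay, at which 2 of the 2 values shown sit. Compound 3 `CONC(=O)[C@H]1CC=C(CCC=C(C)C)C[C@@H]1c1ccccc1` differs from compound 2 by methoxy in place of 2-carboxyethyl on an amide-type nitrogen. Among the measured compounds shown here, no measured step bears on this change, and both measured values sit at the same limit, so nothing in the data points toward a readable gain or loss for compound 3. Compound 3 is therefore expected to remain at or near the limit, with the step that the limit leaves unreadable from compound 2 to compound 3 estimated as showing no movement beyond the scatter. The estimate for compound 3 is 40000 nM, with a range from 15000 nM to 150000 nM.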

Compound 3, inhibition constant: 2400 nM
Estimate against measurement, compound 3: 17-fold (1.22 log units) above, outside the stated range (below it).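

In this assay, compound 3 is the only compound shown that gives a number rather than a limit, so the group on this amide-type nitrogen can change the read-out, which the earlier pair could not show. Methoxy in place of 2-carboxyethyl on an amide-type nitrogen gives an at least 9.5-fold lower number from compound 2 to compound 3 (0.98 log units; beyond the scatter), and methoxyamino in place of dimethylamino on a carbonyl carbon gives an at least 9.5-fold lower number from compound 1 to compound 3 (0.98 log units; beyond the scatter). The step between compound 1 and compound 2 still cannot be read, each of them remaining at a limit: the limit of > 23000 nM in this assay, at which 2 of the 3 values shown sit.

On these data alone, it remains open whether methoxy itself matters, since no other group on this nitrogen, such as hydroxy, ethoxy or a plain methyl, has a value here. As far as these compounds go, the full size of both new steps also stays open: each one has a limit at one end.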